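A few compounds are considered here, and "the series" means these few. Any claim that something is new, unique, unknown or untested is made for them only; others in the source may bear on it.

Of the compounds shown here, three sharing one core have been measured in a functional assay on the whole organism (strain Sprague-Dawley) for inhibition, with Rattus norvegicus as the target, with a stated time of 10 min; on this read-out higher numbers stand for an effect only at larger amounts of compound and lower numbers for an effect already at smaller amounts. Compound 1 `CCOC(=O)c1cnc(-c2ccccc2O)[nH]c1=O`, with hydrogen on the oxygen on the aromatic ring, gives 5 mg/kg. Compound 2 `CCCOc1ccccc1-c1ncc(C(=O)OCC)c(=O)[nH]1`, with propyl on that oxygen, gives 5 mg/kg. Compound 3 `CCOC(=O)c1cnc(-c2ccccc2OC(C)CC)[nH]c1=O`, with sec-butyl there, gives 0.5 mg/kg, the lowest number of the three.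

The next compound, compound 4 `CCOC(=O)c1cnc(-c2ccccc2OCC2CC2)[nH]c1=O`, has cyclopropylmethyl in place of sec-butyl on an oxygen on an aromatic ring.

Going by the values given here, three measured steps bear on this change. Propyl alone gives no change at the digits printed from compound 1 to compound 2 (within the scatter), whereas sec-butyl gives a 10-fold lower number from compound 1 to compound 3 (1.00 log units; beyond the scatter). The methyl that separates the two chains, on the saturated chain carbon bound to the oxygen, gives a 10-fold lower number from compound 2 to compound 3 (1.00 log units; beyond the scatter). Cyclopropylmethyl lacks that methyl, but its ring has no counterpart among the measured compounds, so compound 4 need not fall back fully to the number of compound 2 at 5 mg/kg.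

A moderate move towards a higher number in this assay is therefore expected, and the estimated step is a 3.0-fold higher number from compound 3 to compound 4 (0.48 log units; beyond the scatter). The estimate for compound 4 is 1.5 mg/kg, with an expected range from 0.4 mg/kg to 5 mg/kg.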

Compound 4, dose for 50% inhibition: 0.3 mg/kg
Beside the measured number, compound 4's estimate is 5.0-fold (0.70 log units) above it; the whole stated range lies above it.
By their numbers in this assay, from the lowest: compounds 4 and 3 (each within the scatter of the next); then compounds 1 and 2 (each within the scatter of the next).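

The methyl that set compound 3 apart from compound 2 is not the only route to the low numbers at this oxygen: in this assay, cyclopropylmethyl in place of sec-butyl gives a 1.7-fold lower number from compound 3 to compound 4 (0.22 log units; within the scatter), so this assay does not separate the ring-bearing group from the ring-free one. Measured against the propyl chain, cyclopropyl in place of ethyl gives a 17-fold lower number from compound 2 to compound 4 (1.22 log units; beyond the scatter), and measured against hydrogen on the oxygen, cyclopropylmethyl gives a 17-fold lower number from compound 1 to compound 4 (1.22 log units; beyond the scatter). A group on this oxygen therefore does not lower the number merely by being there, as propyl in compound 2 shows, whereas both sec-butyl and cyclopropylmethyl, neither of them a straight chain, reach the low range.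

Nothing among the data shown explains this difference among the groups. Going by these compounds, it remains open whether a straight butyl chain, a cyclobutylmethyl group or a chain ending in an amine on this oxygen would stay in the range of compound 3 and compound 4 or return to that of compound 1 and compound 2.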